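The source may hold more compounds than are shown below. What is called first, only, known or untested is meant among the compounds shown, and "the series" means these compounds.

Measured so far in a toxicity assay on the whole organism (J774 cells) for cytotoxicity, with Mus musculus as the target, read by MTT assay, with a stated time of 24 h, tested at 30 uM; a lower number here means a stronger effect, a higher number a weaker effect of the compound at the concentration tested:
compound 1, `CCCCCCCCCO[C@@H]1[C@@H](N)[C@@H](O[C@H]2[C@H](O)[C@@H](OCCCCCCCCC)[C@H](N)C[C@@H]2N)O[C@H](CN)[C@H]1O`: 38.8%
compound 2, `CCCCCCCCCO[C@@H]1[C@@H](N)[C@@H](OC[C@H](O)CN=[N+]=[N-])O[C@H](CN)[C@H]1OCCCCCCCCC`: 5.9%

Compound 2 stands lowest of the two numbers in this assay. Its nearest neighbour is compound 1, whose number lies higher by a gap beyond the scatter. Among the compounds with values here, no step between compounds that differ in one place is available for this pair, so the two values show only that compound 1 and compound 2 sit apart in this assay; nothing more can be drawn from them.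

Compound 3, `CCCCCCCCCO[C@@H]1[C@@H](N)[C@@H](OCC(O)CO)O[C@H](CN)[C@H]1OCCCCCCCCC`, is not yet measured. It differs from compound 2 in one place: 1,2-dihydroxyethyl in place of 2-azido-1-hydroxyethyl on a saturated chain carbon bound to an oxygen on a saturated carbon. Within the data shown here, no measured step in this assay resembles this change, so its direction and size cannot be read from the data; the expectation rests on compound 2 alone, at 5.9%.

A modest step of a number 8.1 percentage points higher from compound 2 to compound 3 (within the scatter) is expected, toward a higher number, though a step within the scatter is just as plausible. Compound 3 is accordingly estimated at 14% in this assay, with a range from 3% to 42%.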

Compound 3, a percentage reported as activity, at one concentration (the size of the read-out at that concentration, not a potency): 8.8%
Compound 3: middle estimate off by 5.2 percentage points, on the high side, and the stated range covers the measured number.
By their numbers in this assay, from the lowest: compounds 2 and 3 (each within the scatter of the next); then compound 1.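

In this assay, within the data shown here, putting 1,2-dihydroxyethyl in place of 2-azido-1-hydroxyethyl on a saturated chain carbon bound to an oxygen on a saturated carbon gives a number 2.9 percentage points higher from compound 2 to compound 3 (within the scatter), the only one-place step available so far. At this position, the read-out does not separate the two groups: compound 2 at 5.9% and compound 3 at 8.8% lie within the scatter of each other, so the azido group is not needed for a number in this range in this pair. No measurement at hand explains why the two groups read alike.

Going by these compounds, whether a primary amine or a carboxylic acid at the end of this side chain, or a longer chain in place of 2,3-dihydroxypropyl, would move the number in this assay beyond the scatter remains open. The read-out also comes from one concentration only, so it leaves open whether compound 2 and compound 3 would separate at lower concentrations.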